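Changing the aryl imine group of a thiosemicarbazone

The source may report more compounds than this note shows. Statements on the series, on what has been measured and on what is new or still open speak of the compounds shown alone.

Among the compounds with values here, compound 2 `CC1=CC[C@@H]([C@@](C)(O)CCCC(C)(C)NC(=S)N/N=C\c2cccc(Cl)c2)CC1` holds the higher of the two numbers measured so far in a functional assay on MCF7 cells (Homo sapiens) for cytotoxicity, read by sulforhodamine B assay (on this read-out lower numbers stand for stronger inhibition of growth and higher numbers for weaker inhibition of growth), with compound 2 giving 7350 nM; the nearest is compound 1 `COc1ccc(/C=N\NC(=S)NC(C)(C)CCC[C@](C)(O)[C@@H]2CC=C(C)CC2)cc1`, which in this assay gives 6500 nM, a gap within the scatter. Compound 3 `CC1=CC[C@@H]([C@@](C)(O)CCCC(C)(C)NC(=S)N/N=C(/C)c2ccccc2)CC1` differs from compound 2 by a group of 9 heavy atoms (8 carbon, 1 nitrogen; one six-membered aromatic ring of carbon only) in place of a group of 9 heavy atoms (7 carbon, 1 nitrogen, 1 chlorine; one six-membered aromatic ring of carbon only), on an amide-type nitrogen. Within the data shown here, the only measured step touching this part of the molecule, a 1.1-fold higher number from compound 1 to compound 2 (0.05 log units; within the scatter), likewise exchanged the aromatic group and stayed within the scatter. A step of similar size is therefore expected, a 1.1-fold lower number from compound 2 to compound 3 (0.02 log units; within the scatter), with no clear direction. Compound 3 is estimated at 7000 nM, between 3500 nM and 14000 nM.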

Compound 3, concentration for 50% growth inhibition: 23600 nM
Estimate against measurement, compound 3: 3.4-fold (0.53 log units) below; the whole stated range lies below it.
By their numbers in this assay, from the lowest: compounds 1 and 2 (each within the scatter of the next); then compound 3.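

In this assay this group does change the result, with a 3.2-fold higher number from compound 2 to compound 3 (0.51 log units; beyond the scatter) and a 3.6-fold higher number from compound 1 to compound 3 (0.56 log units; beyond the scatter), both showing weaker growth inhibition and both beyond the scatter. The earlier exchange of ring substituents showed no such change, whereas compound 3 carries a methyl on the carbon with a double bond to nitrogen and a phenyl ring without a substituent. No available evidence accounts for this shift. The compounds shown leave open whether the added methyl, the missing ring substituent or both produce it. As far as these compounds go, how a pyridine ring in place of the phenyl ring would behave also remains open.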